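A Second Chloro on the Way to Compound 4

This account rests on a few compounds, and the source may have more. Where it says the series, first, only, none or still open, it means among the compounds named here.

- compound 1 `Cn1c(N2N=C(c3ccccc3)CC2c2ccccc2)nc(-c2ccccc2)c(C#N)c1=O`: 35400 nM
- compound 2 `Cn1c(N2N=C(c3ccc(Cl)cc3)CC2c2ccccc2)nc(-c2ccccc2)c(C#N)c1=O`: 12300 nM
- compound 3 `COc1ccc(C2CC(c3ccc(Cl)cc3)=NN2c2nc(-c3ccccc3)c(C#N)c(=O)n2C)cc1`: 4800 nM

In a functional assay on MCF7 cells (Homo sapiens) for antiproliferative activity, with a stated time of 72 h (on this read-out higher numbers stand for weaker inhibition and lower numbers for stronger inhibition), compound 2 gives 12300 nM. That places it in the middle of the measured set, with compound 3 lower and compound 1 higher.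

The next compound, compound 4 `Cn1c(N2N=C(c3ccc(Cl)cc3)CC2c2ccccc2)nc(-c2ccc(Cl)cc2)c(C#N)c1=O`, keeps the whole of compound 2 and changes one thing: chloro in place of hydrogen on an aromatic carbon. A phenyl becomes a 4-chlorophenyl, so chloro replaces hydrogen on an aromatic carbon.

Among the compounds with values here, two measured steps bear on this. The same swap, made at another place in the molecule, gave a 2.9-fold lower number from compound 1 to compound 2 (0.46 log units; beyond the scatter). A methoxy in place of hydrogen on an aromatic carbon gave a 2.6-fold lower number from compound 2 to compound 3 (0.41 log units; beyond the scatter). Both steps were modest and both lowered the number, meaning stronger inhibition. Neither was made at the new position, so they offer only a rough guide.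

The expected change is a 2.1-fold lower number from compound 2 to compound 4 (0.31 log units; beyond the scatter), a modest move toward stronger inhibition. For compound 4 the estimated value is 6000 nM, with an expected range of 2500 nM to 14000 nM.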

Compound 4, half-maximal inhibitory concentration: 25300 nM
The estimate for compound 4 lay 4.2-fold (0.62 log units) below the measured number, and the stated range ends below it.
By their numbers in this assay, from the lowest: compound 3; then compound 2; then compounds 4 and 1 (each within the scatter of the next).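

At this position chloro does not repeat what it did elsewhere: on the other aromatic ring, in this assay, the swap gave a 2.9-fold lower number from compound 1 to compound 2 (0.46 log units; beyond the scatter) and here, where a phenyl becomes a 4-chlorophenyl, it gave a 2.1-fold higher number from compound 2 to compound 4 (0.31 log units; beyond the scatter) with the number moving the opposite way. Across these two steps, then, the direction of the change depends on where the chloro sits, so a result from one ring cannot simply be carried over to another. Nothing available here explains this reversal.

From the compounds shown here alone, whether the higher number belongs to chloro in particular or to any group at this place stays open, and a fluoro, an amine or a carboxylic acid on the same carbon could help separate those two readings. Also open, going by these compounds, is whether the same chloro would raise the number when added to compound 3.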